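Swapping a Difluorophenyl Amide Substituent for Pyrimidine

The source may report more compounds than this note shows. Statements on the series, on what has been measured and on what is new or still open speak of the compounds shown alone.

For the measured compounds named here, compound 1 `CC(C)n1ncc2c(C(=O)Nc3cccc(F)c3F)cc(-c3cccs3)nc21` is the only compound with a plain number in an ADME assay on LLC-MK2 cells (Macaca mulatta) for cytotoxicity, read by spectrophotometry and crystal violet staining, with a stated time of 4 days (on this read-out higher numbers stand for lower toxicity in this test and lower numbers for higher toxicity in this test), where compound 1 gives 75000 nM. Compound 2 `CC(C)n1ncc2c(C(=O)Nc3ccccc3F)cc(-c3ccccc3)nc21` in this assay reaches only a limit of the assay, > 200000 nM. Compound 3 `CC(C)n1ncc2c(C(=O)Nc3ncccn3)cc(-c3cccs3)nc21` differs from compound 1 in one place: pyrimidin-2-yl in place of 2,3-difluorophenyl on an amide-type nitrogen. Going by the values given here, no measured pair shows this change, so the step is expected to stay small, probably within the scatter, with the estimate a 1.3-fold higher number from compound 1 to compound 3 (0.12 log units; within the scatter). Compound 3 is therefore expected to give about 100000 nM, between 40000 nM and 200000 nM.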

Compound 3, half-maximal cytotoxic concentration: 75000 nM
For compound 3 the middle estimate is 1.3-fold (0.12 log units) above the measured one; the range from low to high includes it.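

In this assay, putting pyrimidin-2-yl in place of 2,3-difluorophenyl on the amide-type nitrogen gives no change at the digits printed from compound 1 to compound 3 (within the scatter). At this position, then, a ring of carbon only can give way to a ring with 2 hetero atoms and 2 hydrogen-bond acceptors without a readable shift on this read-out. Both compounds give plain numbers rather than a limit, which is not true of every value in the set: the limit of > 200000 nM in this assay, at which 1 of the 3 values shown sits.

Going by these compounds, how a pyridin-2-yl or a cyclohexyl group would read at this place remains open. So does whether the swap would behave the same way with a different group elsewhere on the shared core.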